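The source may hold more compounds than are shown below. What is called first, only, known or untested is meant among the compounds shown, and "the series" means these compounds.

Measured in a functional assay on K562 cells (Homo sapiens) for antiproliferative activity, read by MTT assay; a lower number here means a stronger inhibitor, a higher number a weaker inhibitor:
- compound 1 `O=C1NC(c2ccccc2)CN1S(=O)(=O)c1ccc2c(c1)CCCN2` gives > 20000 nM (a limit)
- compound 2 `CCCOC(=O)N1CCCc2cc(S(=O)(=O)N3CC(c4ccccc4)NC3=O)ccc21` gives > 20000 nM (a limit)
- compound 3 `CC(C)COC(=O)N1CCCc2cc(S(=O)(=O)N3CC(c4ccccc4)NC3=O)ccc21` gives 2380 nM (a number)

Going by the values given here, compound 3 holds the only true number of the three, and the other two values rest at the limit of > 20000 nM in this assay, at which 2 of the 3 values shown sit, as limits. Among the compounds with values here, compound 4 `O=C(CCl)N1CCCc2cc(S(=O)(=O)N3CC(c4ccccc4)NC3=O)ccc21` carries chloromethyl in place of isobutoxy on a carbonyl carbon and no step to it has been measured. Within the data shown here, two measured steps bear on this site: an at least 8.4-fold lower number from compound 1 to compound 3 (0.92 log units; beyond the scatter) for adding isobutoxycarbonyl, and an at least 8.4-fold lower number from compound 2 to compound 3 (0.92 log units; beyond the scatter) for adding one methyl. Since compound 3 owes its number to that group, with an at least 8.4-fold lower number from compound 2 to compound 3 (0.92 log units; beyond the scatter) as the reason, losing isobutoxy is expected to push towards a higher number. The expected step is small, namely a 1.7-fold higher number from compound 3 to compound 4 (0.23 log units; within the scatter) as estimated here. For compound 4 the estimate is 4000 nM with a range of 800 nM to 20000 nM in this assay.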

Compound 4, half-maximal inhibitory concentration: 1100 nM
Compound 4: the middle estimate sits 3.6-fold (0.56 log units) above what was measured; the range from low to high includes it.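

In this assay, going by these compounds alone, chloromethyl in place of isobutoxy on the carbonyl carbon gives a 2.2-fold lower number from compound 3 to compound 4 (0.34 log units; beyond the scatter), so isobutoxy is not the only group there that yields a measurable value. The (chloromethyl)carbonyl group in place of hydrogen gives an at least 18-fold lower number from compound 1 to compound 4 (1.25 log units; beyond the scatter), and chloromethyl in place of propoxy gives an at least 18-fold lower number from compound 2 to compound 4 (1.25 log units; beyond the scatter). Compound 1 and compound 2 each stand at a limit, not a number: the limit of > 20000 nM in this assay, at which 2 of the 4 values shown sit.

On these data alone, what an acetyl or a bromomethyl group on this carbonyl carbon would give remains open, and so does the part played by the chlorine.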